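The compounds below may be only part of what the source reports. "The series", "measured", "known", "first", "only" and "open" are said of these compounds alone.

Measured so far:
compound 1 `C=C1CC[C@@H]2[C@](C)(CO)[C@H](O)CC[C@@]2(C)[C@@H]1CCC1C(=O)OC[C@H]1O` — > 30000 nM
compound 2 `C=C1CC[C@@H]2[C@](C)(CO)[C@H](O)CC[C@@]2(C)[C@@H]1C/C=C(/C(=O)O)[C@H](O)CO` — > 30000 nM
compound 3 `C=C1CC[C@@H]2[C@](C)(CNCc3ccc(F)cc3)[C@H](O)CC[C@@]2(C)[C@@H]1/C=C/C1=CCOC1=O` — 350 nM

In a functional assay on BMMC cells (Mus musculus, strain C57BL/6) for inhibition, with stated times of 5 days and 48 h (a lower number here means a stronger inhibitor, a higher number a weaker inhibitor), compound 1 reaches only a limit, > 30000 nM. Compound 2 likewise gives a limit in this assay, > 30000 nM. Among the compounds with values here, compound 3 is the one compound with a number, 350 nM; the other two values sit at the limit of > 30000 nM in this assay, at which 2 of the 3 values shown sit. Compound 4 `C=C1CC[C@@H]2[C@](C)(CNCc3ccco3)[C@H](O)CC[C@@]2(C)[C@@H]1/C=C/C1=CCOC1=O` carries furan-2-yl in place of 4-fluorophenyl on a saturated chain carbon bound to an amine nitrogen. Within the data shown here, no step between two measured compounds is available, so the size of this change cannot be read from the series. Compound 4 is expected to stay close to compound 3, with a step of a 1.3-fold higher number from compound 3 to compound 4 (0.11 log units; within the scatter) that is estimated to remain within the scatter. The estimate for compound 4 in this assay is 450 nM, between 150 nM and 1500 nM.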

Compound 4, half-maximal inhibitory concentration: 1830 nM
For compound 4 the middle estimate is 4.1-fold (0.61 log units) below the measured one; the measured number lies above the stated range.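

In this assay, within the data shown here, this is the first single change that can be read: on a saturated chain carbon bound to an amine nitrogen, furan-2-yl in place of 4-fluorophenyl gives a 5.2-fold higher number from compound 3 to compound 4 (0.72 log units; beyond the scatter). The read-out therefore responds to the ring carried at this place, and both compounds give a measured number rather than a limit. Nothing measured here gives a cause for this step.

Still open, as far as these compounds go, is whether the fluorine or the ring itself accounts for the step, which an unsubstituted phenyl would help separate. From the compounds shown here alone, the effect of a pyridin-3-yl or a carboxylic acid at this place also remains open.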